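The compounds below may be only part of what the source reports. "The series", "measured", "known", "first", "only" and "open" are said of these compounds alone.

Of the compounds shown here, three have so far been read in an ADME assay on microsomes from liver (Homo sapiens) for pharmacokinetics, read by LC-MS, with a stated time of 60 min, tested at 1 uM (on this read-out lower numbers stand for slow clearance and higher numbers for fast clearance), and their numbers lie close together. In this assay compound 1 `O=C(NCc1ccc(Cl)nc1)Nc1ccc(S(=O)(=O)c2ccccc2)cc1` gives 6 mL/min/kg and compound 2 `Nc1ccc(CNC(=O)Nc2ccc(S(=O)(=O)c3ccccc3)cc2)cn1` gives 5 mL/min/kg, while compound 3 `O=C(NCc1cccnc1)Nc1ccc(S(=O)(=O)N2C3CCC2COC3)cc1` gives 8 mL/min/kg as its value. Compound 3 thus stands within the scatter of both other compounds, and its number cannot be told apart from theirs.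

The next compound, compound 4 `CC1CNCCN(S(=O)(=O)c2ccc(NC(=O)NCc3cccnc3)cc2)C1`, differs from compound 3 in one place only: a group of 8 heavy atoms (6 carbon, 2 nitrogen; one seven-membered non-aromatic ring with 2 hetero atoms) in place of a group of 8 heavy atoms (6 carbon, 1 nitrogen, 1 oxygen; one five-membered non-aromatic ring with 1 hetero atom, one six-membered non-aromatic ring with 2 hetero atoms), on a sulfonyl sulfur is the whole of the change. For the measured compounds named here, the one measured step, a 1.2-fold lower number from compound 1 to compound 2 (0.08 log units; within the scatter), stays within the scatter, but it is amino in place of chloro on an aromatic carbon and does not touch the group on the sulfonyl sulfur. It bears on the new change only loosely. Compounds 1 and 2 also carry a different group on that sulfur from compound 3, and their values still lie within the scatter of its value. Going by the values given here, no measurement yet covers a seven-membered ring there, so no step beyond the scatter is expected in this assay, in either direction. The expected step is no change at the digits printed from compound 3 to compound 4 (within the scatter) and would stay within the scatter. Compound 4 is estimated at 8 mL/min/kg (expected range 4 mL/min/kg to 18 mL/min/kg).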

Compound 4, clearance: 8 mL/min/kg
The estimate for compound 4 equals the measured number at the digits printed, and the stated range covers the measured number.
By their numbers in this assay, from the lowest: compounds 2, 1, 3 and 4 (each within the scatter of the next).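

In this assay, for the compounds shown here, the change on a sulfonyl sulfur whose other neighbour is an aromatic carbon gives no change at the digits printed from compound 3 to compound 4 (within the scatter) and is the first step read at this place, since the one earlier step concerned amino in place of chloro on an aromatic carbon. It shows that the one seven-membered non-aromatic ring with 2 hetero atoms, which brings 1 hydrogen-bond donor where the leaving group has 0, can replace the group with a five-membered and a six-membered non-aromatic ring on that sulfur and leave the clearance number within the scatter. No measurement shown here gives a reason for this result.

The compounds shown leave open whether an open-chain amine, a longer chain or a ring carrying a carboxylic acid on the sulfonyl sulfur would give a step beyond the scatter in this read-out. They also leave open whether amino in place of chloro on an aromatic carbon would stay within the scatter with the seven-membered ring on the sulfonyl sulfur.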